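Moving the chlorine: from compound 2 to compound 3

The source may hold more compounds than are shown below. What is called first, only, known or untested is meant among the compounds shown, and "the series" means these compounds.

Compound 1 `O=C1Nc2ccccc2/C1=N/NC(=S)N1CCN(C(=O)NO)CC1` gives > 100000 nM
Compound 2 `O=C(NO)N1CCN(C(=S)N/N=C/c2ccccc2Cl)CC1` gives > 100000 nM

In a functional assay on U-251 cells (Homo sapiens) for cytotoxicity, read by MTT assay, with a stated time of 48 h (on this read-out higher numbers stand for lower toxicity in this test and lower numbers for higher toxicity in this test), compound 2 stands at > 100000 nM and this is a limit of the assay, not a number. In this assay compound 1 reads > 100000 nM and this too is a limit. Within the data shown here, the measured set therefore sits entirely at the limit of > 100000 nM in this assay, at which 2 of the 2 values shown sit, and offers no measured step to work from.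

Compound 3 `O=C(NO)N1CCN(C(=S)N/N=C/c2ccc(Cl)cc2)CC1` has not yet been measured. It differs from compound 2 in one place, and the two have the same atoms, joined differently. The change is 4-chlorophenyl in place of 2-chlorophenyl on a carbon with a double bond to nitrogen and it falls on a carbon with a double bond to nitrogen.

Compound 2, at its limit of > 100000 nM as the closest reference, suggests that a limit is likely again in this assay for its close relative. The expected move is a number no higher from compound 2 to compound 3 (the limit leaves the size open) and it is estimated to stay within the usual scatter, with no clear direction. For compound 3 the expected value is 100000 nM with an estimated range from 40000 nM to 200000 nM in this test.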

Compound 3, concentration lethal to 50% of the cells: > 100000 nM
Compound 3: only a limit was reported (the forecaster's own chance of this, stated with the estimate: 75%); the middle value lies on the limit itself.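

In this assay compound 3 gives > 100000 nM, which is a limit of the assay and not a number. Compound 2 also stands at a limit, so no step can be read between compound 2 and compound 3. All the compounds shown share one reading: the limit of > 100000 nM in this assay, at which 3 of the 3 values shown sit.

The compounds shown leave open whether 4-chlorophenyl and 2-chlorophenyl differ at all in this assay, and which change, if any, would give a measurable value.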